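The source may hold more compounds than are shown below. What is called first, only, known or untested is meant among the compounds shown, and "the series" means these compounds.

Measured in a functional assay on SK-OV-3 cells (Homo sapiens) for inhibition, read by MTT assay; a lower number here means a stronger inhibitor, a higher number a weaker inhibitor:

- compound 1 `COc1ccc(/C=C2\c3cc(OC)c(OC)c(OC)c3CC[C@@H]2O)cc1F` gives 1 nM
- compound 2 `COc1ccc(/C=C2\c3cc(OC)c(OC)c(OC)c3CC[C@@H]2O)cc1N` gives 740 nM
- compound 3 `COc1ccc(/C=C2\c3cc(OC)c(OC)c(OC)c3CC[C@@H]2O)cc1O` gives 1060 nM

Compound 1 has the lowest number of the three and is the strongest inhibitor in this small set, since its steps to both others lie beyond the scatter. Compound 4 `COc1ccc(/C=C2\c3cc(OC)c(OC)c(OC)c3CC[C@@H]2O)cc1[N+](=O)[O-]` has not yet been measured. It keeps the core of compound 1 but carries nitro in place of fluoro on an aromatic carbon, ortho to a methoxy group (nitro in place of fluoro on an aromatic carbon).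

Two measured steps change this same place. The first is a 740-fold higher number from compound 1 to compound 2 (2.87 log units; beyond the scatter), for amino in place of fluoro. The second is a 1100-fold higher number from compound 1 to compound 3 (3.03 log units; beyond the scatter), for hydroxy in place of fluoro. Both are large, whereas a 1.4-fold higher number from compound 2 to compound 3 (0.16 log units; within the scatter) stays within the scatter, so these two replacements cannot be told apart. Neither of them is nitro, so they offer only an indirect guide. A large rise in the number is still the reasonable expectation, perhaps somewhat smaller than those two steps, and the expected change is a 300-fold higher number from compound 1 to compound 4 (2.48 log units; beyond the scatter). Compound 4 is estimated at 300 nM, with an expected range from 30 nM to 3000 nM.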

Compound 4, half-maximal inhibitory concentration: 4640 nM
Beside the measured number, compound 4's estimate is 15-fold (1.19 log units) below it; measured number above the stated range.
By their numbers in this assay, from the lowest: compound 1; then compounds 2 and 3 (each within the scatter of the next); then compound 4.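

In this assay, nitro turns out to be the poorest replacement for fluoro so far at this aromatic carbon, ortho to a methoxy group, with a 4600-fold higher number from compound 1 to compound 4 (3.67 log units; beyond the scatter) as the step. Amino and hydroxy could not be told apart, which might have suggested that any loss of fluoro led to one shared level, but nitro falls clearly past both: the steps are a 4.4-fold higher number from compound 3 to compound 4 (0.64 log units; beyond the scatter) and a 6.3-fold higher number from compound 2 to compound 4 (0.80 log units; beyond the scatter) in size, modest beside the drop from fluoro, yet beyond the scatter. All three replacements therefore sit far from compound 1 while still differing among themselves, and nothing available here explains this ordering or why fluoro stands so far apart.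

As far as these compounds go, what stays open is whether the low number of compound 1 belongs to fluoro alone or would also appear with chloro, a methyl group or plain hydrogen at this carbon. A nitrile or a trifluoromethyl group there would also show whether nitro's place at the weak end of this set is shared by other groups.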